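Cyclopentyl ether replaced by oxanylamine on the aryl ring

A few compounds are considered here, and "the series" means these few. Any claim that something is new, unique, unknown or untested is made for them only; others in the source may bear on it.

Two compounds share the core and differ only in the group on the aryl oxygen. Compound 1 `CC(C)CCn1ccc(-c2ccc(OCC3CC3)c(Cl)c2)c(C#N)c1=O` in a functional assay on CHO cells for positive allosteric modulation of metabotropic glutamate receptor 2 (Homo sapiens), read by scintillation counting and GTPgammaS binding, with a stated time of 30 min (on this read-out lower numbers stand for an effect already at smaller amounts and higher numbers for an effect only at larger amounts of compound), gives 110 nM; compound 2 `CC(C)CCn1ccc(-c2ccc(OC3CCCC3)c(Cl)c2)c(C#N)c1=O` gives 100 nM. The step of a 1.1-fold lower number from compound 1 to compound 2 (0.04 log units; within the scatter) is the only measured one so far. Compound 2 carries the lower of the two numbers, but its gap to compound 1 is within the scatter, so no order between the two is established.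

Compound 3 `CC(C)CCn1ccc(-c2ccc(NC3CCOCC3)c(Cl)c2)c(C#N)c1=O` is not yet measured. It differs from compound 2 by (oxan-4-yl)amino in place of cyclopentyloxy on an aromatic carbon. For the measured compounds named here, the one measured step bears on it only loosely: it swapped one carbocycle for another on the oxygen and left the number essentially unchanged, whereas here the linking atom itself changes from oxygen to a nitrogen with one hydrogen and a ring bearing a hetero atom enters. Going by the values given here, no measured compound probes that kind of change.

The expectation for compound 3 in this assay is therefore a step of a 1.8-fold higher number from compound 2 to compound 3 (0.26 log units; within the scatter) with wide uncertainty, most likely no change beyond the scatter, estimated at 180 nM within 50 nM to 700 nM.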

Compound 3, half-maximal effective concentration: 174 nM
Compound 3: the middle estimate sits 1.0-fold (0.01 log units) above what was measured; the range from low to high includes it.
By their numbers in this assay, from the lowest: compounds 2, 1 and 3 (each within the scatter of the next).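

In this assay the aromatic carbon ortho to the chloro group accepts a change of a different kind from the earlier swap of one carbocycle for another: with (oxan-4-yl)amino, a nitrogen carrying one hydrogen replaces the linking oxygen and a ring with a hetero atom enters, yet the result is a 1.7-fold higher number from compound 2 to compound 3 (0.24 log units; within the scatter). Measured against cyclopropylmethoxy, the same group gives a 1.6-fold higher number from compound 1 to compound 3 (0.20 log units; within the scatter), so neither step separates it from the two ethers, and the hydrogen-bond donor it brings produces no step beyond the scatter in this series. No supporting data are available to explain this outcome.

Going by these compounds, because the linking atom and the ring change together in compound 3, their separate contributions remain open, and cyclopentylamino or (oxan-4-yl)oxy at this position would be the groups to tell them apart. Also open, on these data alone, is how a group of another kind, such as a carboxylic acid or a longer alkyl chain ending in an amine, would read at the same carbon, and whether these three results would hold with the chloro group replaced by a methyl group.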